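The source may hold more compounds than are shown below. What is called first, only, known or untested is meant among the compounds shown, and "the series" means these compounds.

Measured so far:
- compound 1, `O=C(O)c1cnc(-c2ccccc2F)[nH]c1=O`: 5 mg/kg in a functional assay on the whole organism (strain Sprague-Dawley) for inhibition, with Rattus norvegicus as the target, with a stated time of 10 min; a lower number here means that less compound is needed, a higher number that more compound is needed for the effect
- compound 2, `COc1ccccc1-c1ncc(C(=O)O)c(=O)[nH]1`: 10 mg/kg

Compound 2 has the highest of the two numbers; its nearest neighbour is compound 1, and the step of a 2.0-fold higher number from compound 1 to compound 2 (0.30 log units; within the scatter) stays within the scatter, so the two are not told apart. Among the measured compounds shown here, the unmeasured compound 3, `CCSc1ccccc1-c1ncc(C(=O)O)c(=O)[nH]1`, keeps the whole core of compound 2 and changes only one group on the phenyl ring: ethylsulfanyl in place of methoxy on an aromatic carbon.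

For the measured compounds named here, the one measured step, a 2.0-fold higher number from compound 1 to compound 2 (0.30 log units; within the scatter), also swaps a small group at the same aromatic carbon and produced no change beyond the scatter. Nothing else bears on a sulfur-containing group here, so the expectation rests on that single step. The step from compound 2 to compound 3 is therefore expected to be small, no change at the digits printed from compound 2 to compound 3 (within the scatter), with no clear direction. Compound 3 is estimated at 10 mg/kg, within a range from 4 mg/kg to 25 mg/kg.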

Compound 3, dose for 50% inhibition: 25 mg/kg
For compound 3 the middle estimate is 2.5-fold (0.40 log units) below the measured one, and the stated range covers the measured number.
By their numbers in this assay, from the lowest: compounds 1 and 2 (each within the scatter of the next); then compound 3.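

Among the compounds shown here, at this aromatic carbon, ortho to a large group, the choice of group now shows up in this assay: ethylsulfanyl in place of methoxy gives a 2.5-fold higher number from compound 2 to compound 3 (0.40 log units; beyond the scatter), the first step in this set to pass beyond the scatter. The larger step is the one with ethylsulfanyl in place of fluoro, a 5.0-fold higher number from compound 1 to compound 3 (0.70 log units; beyond the scatter), so more compound is needed with this group than with either earlier one, although the change remains modest. Nothing measured here explains this rise.

As far as these compounds go, it remains open whether the sulfur or the two-carbon chain of ethylsulfanyl accounts for the higher number, which a methylsulfanyl or an ethoxy group at the same carbon would help to separate. From the compounds shown here alone, how an amine or a hydroxyl group there would compare also remains open.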